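The compounds below may be only part of what the source reports. "The series", "measured", "known", "first", "only" and "open" are said of these compounds alone.

Compound 1, `CCCCCCCCCCCCCCOCC1COC(COCCCCCC[n+]2ccsc2)C1`, gives 3.1 mg/kg in a functional assay on artery with platelet-activating factor receptor (Rattus norvegicus) as the target; on this read-out lower numbers stand for an effect already at smaller amounts and higher numbers for an effect only at larger amounts of compound.
Compound 2, `CCCCCCCCCCCCCCOCC1COC(COCCCCCCC[n+]2ccsc2)C1`, gives 1.4 mg/kg in this assay.

Going by the values given here, of the two compounds measured so far, compound 2 has the lower number, and the step of a 2.2-fold lower number from compound 1 to compound 2 (0.35 log units; beyond the scatter) lies beyond the scatter. Compound 3, `CCCCCCCCCCCCOCC1COC(COCCCCCCC[n+]2ccsc2)C1`, is not yet measured. It differs from compound 2 by hydrogen in place of ethyl on a saturated chain carbon, ten or more bonds along the chain from an oxygen on a saturated carbon. Among the compounds with values here, the one measured step, from compound 1 to compound 2, concerns a different place in the molecule, the chain that carries the charged ring, so there is no measured step that bears directly on shortening the long tail. For that reason the expected step of a 1.4-fold higher number from compound 2 to compound 3 (0.15 log units; within the scatter) is kept small, with no confident direction. Compound 3 is therefore estimated at 2 mg/kg in this assay, with a range from 0.9 mg/kg to 4.5 mg/kg.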

Compound 3, dose for 50% inhibition: 3.7 mg/kg
For compound 3 the middle estimate is 1.9-fold (0.27 log units) below the measured one, and the stated range covers the measured number.
By their numbers in this assay, from the lowest: compound 2; then compounds 1 and 3 (each within the scatter of the next).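

The long tail is not a passive part of these molecules: hydrogen in place of ethyl, on a saturated chain carbon, gives a 2.6-fold higher number from compound 2 to compound 3 (0.42 log units; beyond the scatter) in this assay. Going by these compounds alone, the earlier compounds showed a change only in the chain carrying the charged ring, so this is the first sign that the far end of the other chain also affects the dose needed. In both measured steps the compound with the shorter chain has the higher number, and no compound shown goes against this, although two steps make only a thin pattern. Nothing at hand explains the effect of this change.

On these data alone, whether a longer chain at this place would lower the number further or raise it again remains open. So does the effect of a phenyl or hydroxyl group there.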